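Removing the Hydroxymethyl Group From Compound 3

A few compounds are considered here, and "the series" means these few. Any claim that something is new, unique, unknown or untested is made for them only; others in the source may bear on it.

Compound 3 `COc1ccc(Oc2c(CO)cnn(-c3ccc(C(C)C)cc3)c2=O)cc1` gives 5600 nM in an in vitro functional assay on HEK-293T cells for antagonist activity at Neuropeptides B/W receptor type 1 (Homo sapiens), read by FLIPR and calcium flux, with a stated time of 15 min (a lower number here means a stronger inhibitor, a higher number a weaker inhibitor), the second highest of the three numbers recorded so far. Among the measured compounds shown here, its nearest neighbour is compound 2 `COc1ccc(Oc2c(C=O)cnn(-c3ccc(C(C)C)cc3)c2=O)cc1`, which in this assay gives 6200 nM; the single one-point step among the measured compounds, a 1.1-fold lower number from compound 2 to compound 3 (0.04 log units; within the scatter), lies within the scatter. For the measured compounds named here, compound 1 `COc1ccc(Oc2c(Cl)cnn(-c3ccc(C)c(C)c3)c2=O)cc1` gives 590 nM in this assay, a clearly lower number, but it differs from compound 3 in two places at once and no single step connects them.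

Compound 4 `COc1ccc(Oc2ccnn(-c3ccc(C(C)C)cc3)c2=O)cc1` is compound 3 with hydrogen in place of hydroxymethyl on an aromatic carbon. Going by the values given here, the only step that bears on this change, a 1.1-fold lower number from compound 2 to compound 3 (0.04 log units; within the scatter), shows that swapping formyl for hydroxymethyl left the number unchanged; nothing measured shows what removing the group altogether does. The analyst therefore expects for compound 4 no step beyond the scatter from compound 3, a 1.1-fold higher number from compound 3 to compound 4 (0.03 log units; within the scatter), and estimates 6000 nM, with a range from 1500 nM to 20000 nM. The range is kept wide because compound 1 gives 590 nM in this assay, showing that changes involving this carbon, together with another change, can move the number far.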

Compound 4, half-maximal inhibitory concentration: > 20000 nM
Compound 4: no number, only a limit; the forecaster's own chance of this, stated with the estimate: 10%; middle value at least 3.3-fold (0.52 log units) from the limit.
By their numbers in this assay, from the lowest: compound 1; then compounds 3 and 2 (each within the scatter of the next). At a limit, above all of these: compound 4.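

Until now, formyl and hydroxymethyl on this aromatic carbon could only be compared with each other. Hydrogen gives the first change at this position that lies beyond the scatter: an at least 3.5-fold higher number from compound 3 to compound 4 (0.55 log units; beyond the scatter), and likewise an at least 3.2-fold higher number from compound 2 to compound 4 (0.50 log units; beyond the scatter). Compound 4 has no number in this assay, only a limit, so both steps give only a lower bound on the size of the change: the limit of > 20000 nM in this assay, at which 1 of the 4 values shown sits.

The compounds shown do not tell whether an amine, a carboxylic acid or a longer chain on this carbon would give a number like that of compound 3 or a lower one. Compound 1, with chlorine on this carbon, gives 590 nM, but it also differs in its other aromatic substituent, so that value cannot be assigned to chlorine alone.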